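This account rests on a few compounds, and the source may have more. Where it says the series, first, only, none or still open, it means among the compounds named here.

Measured compounds:
compound 1 `c1ccc2c(c1)CN[C@@H](CN(CCCCNCC1CCOCC1)[C@H]1CCCc3cccnc31)C2` — > 30000 nM
compound 2 `O=S1(=O)CCC(CNCCCCN(C[C@H]2Cc3ccccc3CN2)[C@H]2CCCc3cccnc32)CC1` — > 30000 nM
compound 3 `c1ccc2c(c1)CN[C@@H](CN(CCCCNC1CCNCC1)[C@H]1CCCc3cccnc31)C2` — > 30000 nM

In a functional assay on cells for agonist activity at C-X-C chemokine receptor type 4 (Homo sapiens), read by fluorescence and calcium flux, with a stated time of 90 s (on this read-out lower numbers stand for an effect already at smaller amounts and higher numbers for an effect only at larger amounts of compound), each of these values is a limit of the assay, not a number. Compound 3 stands at that limit. Compound 1 and compound 2 sit at the same limit, as the limit of > 30000 nM in this assay, at which 3 of the 3 values shown sit, records. The steps a step that the two limits leave unreadable from compound 1 to compound 2, a step that the two limits leave unreadable from compound 1 to compound 3 and a step that the two limits leave unreadable from compound 2 to compound 3 are all unreadable for this reason, so none of them gives a size or a direction.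

Compound 4 `CC(C)(N)CCCN(C[C@H]1Cc2ccccc2CN1)[C@H]1CCCc2cccnc21` differs from compound 3 by 1-amino-1-methylethyl in place of ((piperidin-4-yl)amino)methyl on a saturated chain carbon, three bonds along the chain from an amine nitrogen. Within the data shown here, no measured step bears on this change, since every measured step runs between limits. Compound 4 is expected, with wide uncertainty, to show a step of an at least 1.5-fold lower number from compound 3 to compound 4 (0.17 log units; that floor lies within the scatter) in this assay. The value of compound 4 is estimated at 20000 nM, within 3000 nM to 60000 nM, with a fair chance that only a limit is again reported.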

Compound 4, half-maximal effective concentration: > 30000 nM
Compound 4: only a limit was reported (the forecaster's own chance of this, stated with the estimate: 65%); middle value at least 1.5-fold (0.17 log units) from the limit.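

In this assay compound 4 gives > 30000 nM, a limit and not a number. Among these compounds, no step from compound 1, compound 2 or compound 3 to compound 4 can be read: the limit of > 30000 nM in this assay, at which 4 of the 4 values shown sit. The compounds shown leave open whether any group at this place gives a measurable value.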